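Adding a Methyl to the Hydroxy of Compound 3

The compounds below may be only part of what the source reports. "The series", "measured", "known", "first", "only" and "open" are said of these compounds alone.

- Compound 1 `Oc1cccc(-c2nc(-c3ccccc3)c(-c3ccccc3)[nH]2)c1`: 61800 nM
- Compound 2 `Oc1ccc(-c2nc(-c3ccccc3)c(-c3ccccc3)[nH]2)cc1O`: 59400 nM
- Compound 3 `COc1cc(-c2nc(-c3ccccc3)c(-c3ccccc3)[nH]2)cc(OC)c1O`: 264000 nM

In a functional assay on brain, read by spectrophotometry (a lower number here means a stronger inhibitor, a higher number a weaker inhibitor), compound 3 gives 264000 nM. This is the highest number of the three and marks the weakest inhibitor, with a gap beyond the scatter to both compound 1 and compound 2.

Compound 4 `COc1cc(-c2nc(-c3ccccc3)c(-c3ccccc3)[nH]2)cc(OC)c1OC` makes a single change: methyl in place of hydrogen on an oxygen on an aromatic ring. A methyl takes the place of hydrogen on an oxygen on an aromatic ring, so hydroxy becomes methoxy.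

Within the data shown here, no measured pair shows this exact change. The nearest evidence is one step, a 1.0-fold lower number from compound 1 to compound 2 (0.02 log units; within the scatter), where hydroxy replaces hydrogen on an aromatic carbon, and that step stays within the scatter. It is a different change and only weak guidance, so no step beyond the scatter is expected in this assay, and the range is kept wide.

The estimated step is a 1.2-fold lower number from compound 3 to compound 4 (0.08 log units; within the scatter).

Compound 4 is estimated at 220000 nM, with an expected range from 80000 nM to 600000 nM.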

Compound 4, half-maximal inhibitory concentration: 61300 nM
Estimate against measurement, compound 4: 3.6-fold (0.55 log units) above; measured number below the stated range.
By their numbers in this assay, from the lowest: compounds 2, 4 and 1 (each within the scatter of the next); then compound 3.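

In this assay, putting a methyl in place of the hydrogen on this oxygen, so that hydroxy becomes methoxy, gives a 4.3-fold lower number from compound 3 to compound 4 (0.63 log units; beyond the scatter) and so a stronger inhibitor. A free hydroxy at this place is therefore not needed for inhibition in this pair, and this is the first single change shown to move the number beyond the scatter, whereas the earlier step, a 1.0-fold lower number from compound 1 to compound 2 (0.02 log units; within the scatter), stays within it. No measurement shown here accounts for this shift.

As far as these compounds go, it remains open whether a longer chain on this oxygen, such as ethyl, would give a similar number, and what an amine in place of the methoxy would do. Also open, from the compounds shown here alone, is whether a methyl on the hydroxy of compound 1 or compound 2 would change the number in the same way.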